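Amino for bromo on the quinone ring of compound 3

This account rests on a few compounds, and the source may have more. Where it says the series, first, only, none or still open, it means among the compounds named here.

Measured compounds:
Compound 1 `CSc1nc2c([nH]1)C(=O)C=C(N(C)C)C2=O`, in a functional assay on MCF7 cells (Homo sapiens) for antiproliferative activity; a higher number here means a weaker inhibitor, a lower number a stronger inhibitor: > 90 uM
Compound 2 `CSc1nc2c([nH]1)C(=O)C=C(Br)C2=O`, in this assay: 62.8 uM
Compound 3 `O=C1C(Br)=CC(=O)c2[nH]c(-c3ccccn3)nc21`, in this assay: > 90 uM

Compound 3 stands at a limit of this assay rather than at a number; compound 1 also reports a limit. Compound 4 `NC1=CC(=O)c2[nH]c(-c3ccccn3)nc2C1=O` differs from compound 3 only by amino in place of bromo on a double-bonded ring carbon.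

Among the compounds with values here, two measured steps bear on this. Moving an at least 1.4-fold lower number from compound 1 to compound 2 (0.15 log units; that floor lies within the scatter) replaced an amino-type group at this same position with bromo and gave, at most, a small gain; its size is only a floor due to the limit of > 90 uM in this assay, at which 2 of the 3 values shown sit. Moving an at least 1.4-fold higher number from compound 2 to compound 3 (0.15 log units; that floor lies within the scatter) changed the other position and returned to the limit. Within the data shown here, compound 4 reverses the first kind of change on the core of compound 3, so no gain beyond the scatter is expected, and a limit again seems most likely.

Compound 4 is therefore estimated at 120 uM, within 40 uM to 400 uM, a step that the limit leaves unreadable from compound 3 to compound 4 that is expected to stay within the scatter.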

Compound 4, concentration for 50% inhibition: > 90 uM
Compound 4 ended at the assay's limit (the forecaster's own chance of this, stated with the estimate: 70%); the middle value does not contradict the limit.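

In this assay compound 4 gives > 90 uM, a limit and not a number. Compound 3 also stands at a limit, so no step can be read between compound 3 and compound 4: the limit of > 90 uM in this assay, at which 3 of the 4 values shown sit.

The compounds shown leave open how amino and bromo compare on the core of compound 3.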